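Compound 2 to compound 3: one group changes

A few compounds are considered here, and "the series" means these few. Any claim that something is new, unique, unknown or untested is made for them only; others in the source may bear on it.

- Compound 1 `CCN1CCN(C(=S)SCC(=O)N(Cc2ccc(OC)cc2)c2cc(OC)c(OC)c(OC)c2)CC1`: 3070 nM
- Compound 2 `COc1cc(N(Cc2ccc(C)cc2)C(=O)CSC(=S)N2CCN(C(=O)OC(C)(C)C)CC2)cc(OC)c1OC`: > 20000 nM (a limit)

Both values come from a functional assay on KYSE-450 cells (Homo sapiens) for inhibition, read by CCK-8 assay, with a stated time of 48 h; on this read-out lower numbers stand for stronger inhibition and higher numbers for weaker inhibition. For the measured compounds named here, compound 1 is the only compound here with a measured number, at 3070 nM. Compound 2 reads > 20000 nM, which is a limit of the assay and not a number. Compound 2 therefore sits at the limit of > 20000 nM in this assay, at which 1 of the 2 values shown sits.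

Compound 3 `COc1ccc(CN(C(=O)CSC(=S)N2CCN(C(=O)OC(C)(C)C)CC2)c2cc(OC)c(OC)c(OC)c2)cc1N` is compound 2 with a single group exchanged: 3-amino-4-methoxyphenyl in place of 4-methylphenyl on a saturated chain carbon bound to an amide-type nitrogen. In words, 3-amino-4-methoxyphenyl takes the place of 4-methylphenyl on a saturated chain carbon bound to an amide-type nitrogen.

Going by the values given here, no measured pair of compounds shows this exchange on its own, so any forecast is uncertain. A clear move towards stronger inhibition in this assay is expected, beyond the usual scatter, although compound 3 could also stay at the limit. Among the compounds with values here, the only support is that compound 1 reaches a real number, at 3070 nM. The estimated change is an at least 8.0-fold lower number from compound 2 to compound 3 (0.90 log units; beyond the scatter). For compound 3 the estimated value is 2500 nM, with an expected range of 250 nM to 20000 nM.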

Compound 3, half-maximal inhibitory concentration: 208 nM
Estimate against measurement, compound 3: 12-fold (1.08 log units) above; measured number below the stated range.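

In this assay, for the compounds shown here, 3-amino-4-methoxyphenyl in place of 4-methylphenyl on a saturated chain carbon bound to an amide-type nitrogen gives an at least 96-fold lower number from compound 2 to compound 3 (1.98 log units; beyond the scatter), and this is the first step here in which only one group differs. With the rest of the molecule unchanged, this one position separates a compound with no measurable value in the tested range from compound 3 at 208 nM, so the group held there matters greatly in these cells. Compound 2 gives only a limit and not a number, so the true size of the step could be larger than printed: the limit of > 20000 nM in this assay, at which 1 of the 3 values shown sits.

The exchange adds an amine and a methoxy group together and removes a methyl group, so these two compounds cannot show which of these differences carries the gain, or whether the two added groups are both needed. On these data alone, whether a 3-aminophenyl group alone, or a 3-hydroxy-4-methoxyphenyl group with a hydroxyl in place of the amine, would perform like 3-amino-4-methoxyphenyl remains open.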